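This account rests on a few compounds, and the source may have more. Where it says the series, first, only, none or still open, it means among the compounds named here.

Measured so far in a functional assay on cells (leukaemia cell line, Homo sapiens) for inhibition, read by sulforhodamine B assay, with a stated time of 48 h; on this read-out lower numbers stand for stronger inhibition of growth and higher numbers for weaker inhibition of growth:

Compound 1 `O=S(=O)(Nc1ccc(Cl)c(Cl)c1)c1ccc(-c2cnc(C3CC3)o2)cc1`: 62100 nM
Compound 2 `O=S(=O)(Nc1ccc(Cl)cc1Cl)c1ccc(-c2cnc(C3CC3)o2)cc1`: 74500 nM

In this assay compound 2 stands at 74500 nM, and its number cannot be told apart from that of compound 1. Both compounds therefore show only weak inhibition of growth on the evidence so far.

The next compound, compound 3 `O=S(=O)(Nc1ccccc1Cl)c1ccc(-c2cnc(C3CC3)o2)cc1`, has not yet been measured. It differs from compound 2 by a single small change: hydrogen in place of chloro on an aromatic carbon. In words, this is hydrogen in place of chloro on an aromatic carbon, so that 2,4-dichlorophenyl becomes 2-chlorophenyl.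

For the measured compounds named here, only one measured step bears on this change: a 1.2-fold higher number from compound 1 to compound 2 (0.08 log units; within the scatter). That step swaps 3,4-dichlorophenyl for 2,4-dichlorophenyl on the sulfonamide nitrogen, and both compounds keep two chloro groups. The data therefore hold no direct measure of what losing a chloro group does, and this calls for a wide range.

With so little to go on, no shift beyond the scatter is expected, and the expected change is a 1.1-fold higher number from compound 2 to compound 3 (0.03 log units; within the scatter).

For compound 3 the estimated value is 80000 nM, with an expected range from 45000 nM to 130000 nM.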

Compound 3, concentration for total growth inhibition: 49700 nM
Compound 3: the middle estimate sits 1.6-fold (0.21 log units) above what was measured; low and high end bracket the measured number.
By their numbers in this assay, from the lowest: compounds 3, 1 and 2 (each within the scatter of the next).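

For the compounds shown here, the change from 2,4-dichlorophenyl to 2-chlorophenyl gives the first direct look at losing a chloro group in this assay, and it amounts to a 1.5-fold lower number from compound 2 to compound 3 (0.18 log units; within the scatter), which lies within the usual scatter, so this chloro group, meta to a chloro group and para to a large group, can be removed with no change that these data can detect. Taking both chloro groups of the 3,4-dichlorophenyl compound away and placing a single chloro group elsewhere on the ring gives a 1.2-fold lower number from compound 1 to compound 3 (0.10 log units; within the scatter), also within the scatter, so the three chloro patterns shown cannot be told apart and all three compounds remain weak inhibitors of growth. No measurement is available that could explain these numbers.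

Going by these compounds, it remains open whether a group of another kind at this position, such as an amine, a carboxylic acid or a methoxy group, would move the number beyond the scatter. Also unsettled is what a plain phenyl ring without any chloro group would give, and whether changes elsewhere, such as replacing the cyclopropyl group with a longer chain, matter more than the chloro pattern.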